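Triazole aryl swap and cytotoxicity across the series

A few compounds are considered here, and "the series" means these few. Any claim that something is new, unique, unknown or untested is made for them only; others in the source may bear on it.

Compound 1 `COc1cc(O)c(C(=O)/C=C/c2ccc(OC)c(OCc3cn(-c4ccc(F)cc4F)nn3)c2)c(OC)c1` is the reference point of this step. In an ADME assay on Huh-7 cells (Homo sapiens) for cytotoxicity, read by MTT assay, with a stated time of 72 h (on this read-out higher numbers stand for lower toxicity in this test and lower numbers for higher toxicity in this test), compound 1 gives > 100 ug/mL, which is a limit of the assay and not a number. Compound 2 `COc1cc(OC)c2c(=O)cc(-c3ccc(OCc4cn(-c5ccc(F)c(Cl)c5)nn4)c(OC)c3)oc2c1` shows the same outcome: in this assay compound 2 gives > 100 ug/mL, again a limit. Going by the values given here, compound 1 therefore stands with every value shown at the limit of > 100 ug/mL in this assay, at which 2 of the 2 values shown sit; no step between measured compounds exists, so nothing is known of how any structural change moves this read-out.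

Compound 3 `COc1cc(O)c(C(=O)/C=C/c2ccc(OC)c(OCc3cn(-c4ccc(Cl)cc4)nn3)c2)c(OC)c1` differs from compound 1 by 4-chlorophenyl in place of 2,4-difluorophenyl on an aromatic nitrogen, in words 4-chlorophenyl in place of 2,4-difluorophenyl on an aromatic nitrogen. With both measured values sitting at the limit, no step beyond the scatter is expected in this assay in either direction. Compound 3 is accordingly expected to give 120 ug/mL in this assay, within 60 ug/mL to 300 ug/mL, and most likely to be reported again only as a limit. The expected step that the limit leaves unreadable from compound 1 to compound 3 is estimated as none beyond the scatter.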

Compound 3, half-maximal cytotoxic concentration: > 100 ug/mL
Compound 3: only a limit was reported; the forecaster's own chance of this, stated with the estimate: 85%; the middle value is on the limit's open side.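

In this assay compound 3 gives > 100 ug/mL, a limit and not a number. Going by these compounds alone, compound 1 and compound 3 both stand at limits, and no step between them can be read. Left open is where the half-maximal cytotoxic concentration of any compound shown lies, and whether the aryl swap moves it: the limit of > 100 ug/mL in this assay, at which 3 of the 3 values shown sit.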